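A Urea Ring Replaces a Methylcyclohexyl Amide

This account rests on a few compounds, and the source may have more. Where it says the series, first, only, none or still open, it means among the compounds named here.

Of the compounds shown here, three built on one shared core have been tested in an assay on HEK293 cells for negative allosteric modulation of metabotropic glutamate receptor 5 (Homo sapiens), read by FLIPR; on this read-out higher numbers stand for weaker inhibition and lower numbers for stronger inhibition. Compound 1 `O=C(c1ccc(F)c(F)c1)N1CC(c2nc(-c3cccc(F)c3)no2)C1` gives only the limit > 10000 nM, not a number. Compound 3 `Cc1cccc(-c2noc(C3CN(C(=O)c4cccc(F)c4)C3)n2)c1` gives 2100 nM. Compound 2 `CC1CCC(C(=O)N2CC(c3nc(-c4cccc(Cl)c4)no3)C2)CC1` likewise returns only the limit > 10000 nM, so no number is known for it. Compound 2 thus stands at the limit of > 10000 nM in this assay, at which 2 of the 3 values shown sit, and only compound 3 has a measured number among the three.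

Compound 4 `O=C(N1CCCCCC1)N1CC(c2nc(-c3cccc(Cl)c3)no2)C1` differs from compound 2 in one place: azepan-1-yl in place of 4-methylcyclohexyl on a carbonyl carbon. Among the measured compounds shown here, no measured pair in this set differs in a single place, so the size of such a step cannot be read from the data; the starting point is itself a limit, and the other compound at that limit, compound 1, carries a different group at the same carbonyl carbon.

The step is expected to be a step that the limit leaves unreadable from compound 2 to compound 4, that is, no movement beyond the scatter is expected. For compound 4 the estimate in this assay is 15000 nM, with a range from 4000 nM to 50000 nM, and it is quite possible that this assay again reports only a limit.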

Compound 4, half-maximal inhibitory concentration: > 10000 nM
Compound 4 was reported as a limit; the forecaster's own chance of this, stated with the estimate: 65%; the middle value is on the limit's open side.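

In this assay compound 4 gives > 10000 nM, which is a limit and not a number. Compound 2 stands at a limit too: the limit of > 10000 nM in this assay, at which 3 of the 4 values shown sit. Among the compounds shown here, no step from compound 2 to compound 4 can therefore be read. On these data alone, whether azepan-1-yl or 4-methylcyclohexyl on the carbonyl carbon gives stronger inhibition remains open.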